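The source may hold more compounds than are shown below. What is called first, only, known or untested is meant among the compounds shown, and "the series" means these compounds.

Measured compounds:
- compound 1, `Cc1ccc(-n2cc(C(=O)Nc3cc(F)cc(F)c3)c(=O)c3ccc(N(C)C)nc32)cc1OCCCCCCC[n+]1ccccc1`, giving 39.7% in an assay on LX2 cells for inhibition of COL1A1 promoter (Homo sapiens), read by a luciferase reporter, with a stated time of 24 h, tested at 20 uM; a higher number here means a stronger effect of the compound at the concentration tested, a lower number a weaker effect
- compound 2, `CN(C)c1ccc2c(=O)c(C(=O)Nc3cc(F)cc(F)c3)cn(-c3ccc(Cl)c(OCCCCCCC[n+]4ccccc4)c3)c2n1`, giving "not active" (no number reported) in this assay

Among the measured compounds shown here, compound 1 is the only compound with a number in this assay; compound 2 carries no number there, only the statement that it is not active, so the two cannot be set against each other in size. Compound 3, `Cc1ccc(-n2cc(C(=O)Nc3cc(F)cc(F)c3)c(=O)c3ccc(N(C)C)nc32)cc1OCCCCCCC[N+](C)(C)C1CCCCC1`, has not yet been measured in this assay. It differs from compound 1 in one place: a group of 9 heavy atoms (8 carbon, 1 nitrogen; one six-membered non-aromatic ring of carbon only) in place of a group of 6 heavy atoms (5 carbon, 1 nitrogen; one six-membered aromatic ring with 1 hetero atom), on a saturated chain carbon, seven bonds along the chain from an oxygen on an aromatic ring. For the measured compounds named here, no step between measured compounds is known, so there is nothing to say how far such a change at the end of the chain moves the read-out. The expectation is therefore a step of modest size in this assay, in either direction, and possibly none beyond the scatter. On that basis compound 3 is expected to give about 35%, within a range from 10% to 60%, which corresponds to an expected step of a number 4.7 percentage points lower from compound 1 to compound 3 (within the scatter).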

Compound 3, a percentage reported as inhibition, at one concentration (the size of the read-out at that concentration, not a potency): 32.3%
Estimate against measurement, compound 3: 2.7 percentage points above, within the range that was stated.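

The end of the chain, on a saturated chain carbon seven bonds along the chain from an oxygen on an aromatic ring, now has its first measured step: in this assay, putting the group with one six-membered non-aromatic ring of carbon only in place of the group with one six-membered aromatic ring with 1 hetero atom gives a number 7.4 percentage points lower from compound 1 to compound 3 (within the scatter). At this position, then, a group of 9 heavy atoms instead of 6, without an aromatic ring and with net charge +1 in both cases, leaves the two compounds indistinguishable in this read-out. No measurement at hand accounts for this result.

One step cannot show whether a different group at the chain end, such as a carboxylic acid or a primary amine, would move the read-out beyond the scatter. From the compounds shown here alone, how a longer chain would compare also remains open.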